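A few compounds are considered here, and "the series" means these few. Any claim that something is new, unique, unknown or untested is made for them only; others in the source may bear on it.

Compound 1 `CCC(C)(C)Cc1c[nH]c(CCc2ccc(-c3cnccn3)cc2)n1` and compound 2 `CCC(C)(C)Cc1c[nH]c(CCc2ccc(N3CCCCC3)cc2)n1` share one core and differ only in the group attached to an aromatic carbon. In an in vitro assay on CHO cells for displacement of a labelled ligand from Bombesin receptor subtype-3 (Homo sapiens), read by scintillation counting, with a stated time of 2 h (on this read-out lower numbers stand for stronger inhibition and higher numbers for weaker inhibition), compound 1 gives 51 nM, and compound 2 gives 28 nM. Within the data shown here, of these two numbers compound 1 has the higher one, but the only step measured so far, a 1.8-fold lower number from compound 1 to compound 2 (0.26 log units; within the scatter), is small enough to count as noise rather than a real difference. Compound 3 `CCC(C)(C)Cc1c[nH]c(CCc2ccc(-n3cncn3)cc2)n1` is the unmeasured compound: 1H-1,2,4-triazol-1-yl in place of pyrazin-2-yl on an aromatic carbon. Among the measured compounds shown here, the one measured step bears on it only loosely, since there the same pyrazin-2-yl gave way to piperidin-1-yl rather than to 1H-1,2,4-triazol-1-yl, and that swap hardly moved the number. Nothing in the measured data shows a large effect from changing this group, so the expectation for compound 3 is a step of a 1.0-fold lower number from compound 1 to compound 3 (0.01 log units; within the scatter), staying within the scatter. The estimate for compound 3 in this assay is therefore 50 nM, with a likely range from 20 nM to 130 nM.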

Compound 3, half-maximal inhibitory concentration: 340 nM
Estimate against measurement, compound 3: 6.8-fold (0.83 log units) below; the measured number lies above the stated range.
By their numbers in this assay, from the lowest: compounds 2 and 1 (each within the scatter of the next); then compound 3.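

The earlier pair suggested that this position, on an aromatic carbon of a six-membered aromatic ring of carbon only, tolerates very different groups, yet in this assay the position proves sensitive to the group it carries: 1H-1,2,4-triazol-1-yl gives a clearly weaker result than pyrazin-2-yl (a 6.7-fold higher number from compound 1 to compound 3 (0.82 log units; beyond the scatter)) and than piperidin-1-yl (a 12-fold higher number from compound 2 to compound 3 (1.08 log units; beyond the scatter)). This single change alters the ring size, from six-membered to five-membered, and also the number of ring nitrogens, so the step cannot show which of these differences matters, if either does. Nothing measured here accounts for the rise in the number.

The compounds shown leave open whether another five-membered aromatic ring with fewer nitrogens, such as pyrazol-1-yl or imidazol-1-yl, would stay close to compound 1 or fall towards compound 3. They also leave open how a morpholin-4-yl ring, an open-chain dimethylamino group or a carboxylic acid would fare at this position.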